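Inverting the stereocentre of compound 2

The source may hold more compounds than are shown below. What is called first, only, known or untested is meant among the compounds shown, and "the series" means these compounds.

In a functional assay on the whole organism with Mus musculus as the target (on this read-out higher numbers stand for an effect only at larger amounts of compound and lower numbers for an effect already at smaller amounts), compound 1 `O=C1CC[C@@H](NC(=O)OCc2ccccc2)C(=O)N1` gives 56.3 mg/kg and compound 2 `CN1C(=O)C[C@@H](NC(=O)OCc2ccccc2)C1=O` gives 52.5 mg/kg and these two values lie within the scatter of each other. Compound 3 `CN1C(=O)C[C@H](NC(=O)OCc2ccccc2)C1=O` differs from compound 2 in configuration only (the two compounds have the same atoms and bonds and differ only in configuration as drawn: 1 of 1 stereo elements differ; a stereocentre at a saturated ring carbon is drawn R in compound 2 and S in compound 3). A stereocentre at a saturated ring carbon is drawn R in compound 2 and S in compound 3. For the measured compounds named here, no measured pair shows such an inversion, so no direction is favoured and a step within the scatter is expected. The estimate means an expected 1.1-fold higher number from compound 2 to compound 3 (0.06 log units; within the scatter) in this read-out. The estimated value for compound 3 is 60 mg/kg with a range from 30 mg/kg to 125 mg/kg as its expected span.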

Compound 3, dose for half-maximal effect: 61.2 mg/kg
Estimate against measurement, compound 3: 1.0-fold (0.01 log units) below, and the stated range covers the measured number.
By their numbers in this assay, from the lowest: compounds 2, 1 and 3 (each within the scatter of the next).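

In this assay, going from R to S at the saturated ring carbon gives a 1.2-fold higher number from compound 2 to compound 3 (0.07 log units; within the scatter), so at this position the two drawn configurations cannot be told apart on this read-out. For the compounds shown here, this is the first step that reads the configuration at this carbon on its own, since nothing else changes: the fact that compounds 2 and 3 differ only in the configuration as drawn.

On these data alone, it remains open whether inversion reads the same on the core of compound 1. Also open, as far as these compounds go, is how this read-out responds to an amine or a carboxylic acid in place of the carbamate.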